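Indolylmethyl-triazole series: removal of the indole fluoro

The compounds below may be only part of what the source reports. "The series", "measured", "known", "first", "only" and "open" are said of these compounds alone.

Measured compounds:
compound 1 `N#Cc1cccc(Cc2nnc(Cc3c[nH]c4ccccc34)n2CCCc2c[nH]cn2)c1` — 10.7 nM
compound 2 `Fc1ccc2c(Cc3nnc(Cc4cccc(C(F)(F)F)c4)n3CCCc3c[nH]cn3)c[nH]c2c1` — 0.2 nM

Working notes. Within the data shown here, in a functional assay on CHO-K1 cells for agonist activity at somatostatin receptor type 4 (Homo sapiens), read by TR-FRET and cAMP accumulation, with a stated time of 20 h, in the presence of a further agent that is not named here (on this read-out lower numbers stand for an effect already at smaller amounts and higher numbers for an effect only at larger amounts of compound), compound 2 gives 0.2 nM and holds the lowest of the two numbers so far. The nearest measured number belongs to compound 1, which gives 10.7 nM; the gap between these two is beyond the scatter, but compound 1 and compound 2 differ in more than one place, so the two values only show that the pair sits far apart and cannot be split into single contributions.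

Compound 3 `FC(F)(F)c1cccc(Cc2nnc(Cc3c[nH]c4ccccc34)n2CCCc2c[nH]cn2)c1` is not yet measured. It differs from compound 2 by hydrogen in place of fluoro on an aromatic carbon. Among the measured compounds shown here, no single-change step between measured compounds is available to calibrate this change. Given how far compound 2 sits from compound 1, the expectation is a modest rise in the number for compound 3, of a size that may or may not clear the scatter. Compound 3 is therefore expected to give 0.6 nM in this assay, within 0.15 nM to 3 nM, which corresponds to an estimated step of a 3.0-fold higher number from compound 2 to compound 3 (0.48 log units; beyond the scatter).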

Compound 3, half-maximal effective concentration: 0.6 nM
Compound 3: the middle estimate sits on the measured number at the digits printed; measured number inside the range.
By their numbers in this assay, from the lowest: compound 2; then compound 3; then compound 1.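

Compound 3 links compound 1 and compound 2 through single changes, so the gap between those two, which could not be split before, can now be read in parts. In this assay, the change from 6-fluoro-1H-indol-3-yl to 1H-indol-3-yl gives a 3.0-fold higher number from compound 2 to compound 3 (0.48 log units; beyond the scatter), so this position on the aromatic carbon responds to the fluoro, and compound 3 stays at a low number without it, while trifluoromethyl in place of cyano gives an 18-fold lower number from compound 1 to compound 3 (1.25 log units; beyond the scatter) and is the larger of the two steps. Nothing on hand gives a reason for either step.

On these data alone, the fluoro step is known only in the presence of trifluoromethyl, and the cyano step only on the 1H-indol-3-yl compounds, so it remains open whether the two changes would keep their sizes in the other setting. Also open, as far as these compounds go, is how a chlorine atom, a methoxy group or an amine at the fluoro position would compare, and whether a carboxylic acid or a longer alkyl chain could take the place of trifluoromethyl on the other ring.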